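The compounds below may be only part of what the source reports. "The series", "measured", "known", "first", "only" and "open" are said of these compounds alone.

Compound 1 `COc1ccc(C(=O)c2ccc(OC)c3c2OC(C)(C)C=C3)c(NC(=O)CN)c1` and compound 2 `COc1ccc(C(=O)c2ccc(OC)c3c2C=CC(C)(C)O3)c(NC(=O)CN)c1` carry the same atoms joined differently, and the difference between the two cores is not broken down here. In a functional assay on HCT-8 cells (Homo sapiens) for antiproliferative activity, read by MTT assay, with a stated time of 48 h (a lower number here means a stronger inhibitor, a higher number a weaker inhibitor), compound 1 gives 370 nM, while compound 2 gives 1050 nM, a number that stands highest of the three measured compounds and beyond the scatter from compound 1. Compound 3 `CNCC(=O)Nc1cc(OC)ccc1C(=O)c1ccc(OC)c2c1OC(C)(C)C=C2` is made from compound 1 by the change (methyl in place of hydrogen on an amine nitrogen), and in this assay compound 3 gives 740 nM; the step of a 2.0-fold higher number from compound 1 to compound 3 (0.30 log units; within the scatter) lies within the scatter, so the two cannot be ordered. Compound 3 and compound 2 also lie within the scatter of each other.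

Compound 4 `CNCC(=O)Nc1cc(OC)ccc1C(=O)c1ccc(OC)c2c1C=CC(C)(C)O2` has not yet been measured. It arises from compound 2 by the change (methyl in place of hydrogen on an amine nitrogen), the same kind of change as that from compound 1 to compound 3, made here on the core of compound 2. Because the step of a 2.0-fold higher number from compound 1 to compound 3 (0.30 log units; within the scatter) was small, compound 4 is expected to show a step of about a 1.7-fold higher number from compound 2 to compound 4 (0.23 log units; within the scatter) in this assay, a rise of similar size that may still fall within the scatter. Among the measured compounds shown here, compound 4 is therefore estimated at 1800 nM, with a range from 900 nM to 4000 nM that allows for the scatter of this kind of measurement and for the fact that only one earlier instance of the change is available.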

Compound 4, half-maximal inhibitory concentration: 3460 nM
The estimate for compound 4 lay 1.9-fold (0.28 log units) below the measured number; the measured number falls inside the stated range.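

In this assay, methyl in place of hydrogen on the amine nitrogen of compound 2 gives a 3.3-fold higher number from compound 2 to compound 4 (0.52 log units; beyond the scatter), and this step can be set beside the same change on the other core: the same change on two cores in this assay, a 2.0-fold higher number (0.30 log units; within the scatter) from compound 1 to compound 3 and a 3.3-fold higher number (0.52 log units; beyond the scatter) from compound 2 to compound 4, 1.6-fold (0.22 log units) apart, within the scatter of two such steps. The gap between the two steps lies within the scatter, so the data give no sign that the size of the change depends on which of these two cores carries it, and the result on the core of compound 1 offers a fair first guide to the result on the core of compound 2. Among the compounds shown here, this does not show that the two steps are equal, for only the step to compound 4 lies beyond the scatter, and two instances on two closely related cores make no rule for the wider series and say nothing about why the numbers differ.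

The compounds shown leave open how an ethyl group, or a second methyl giving a dimethylamino group, on the same amine nitrogen would read on either core. They also leave open whether a longer chain between the carbonyl and the amine, or a ring amine such as pyrrolidine, would follow the same course on both cores.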